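The source may hold more compounds than are shown below. What is called first, only, known or untested is meant among the compounds shown, and "the series" means these compounds.

Measured compounds:
compound 1 `CC(O)(CSc1ccc(C(F)(F)F)cc1)C(=O)Nc1cccc(S(F)(F)(F)(F)F)c1`: 27300 nM
compound 2 `CC(O)(CSc1ccccc1C(F)(F)F)C(=O)Nc1cccc(S(F)(F)(F)(F)F)c1`: 21000 nM
compound 3 `CC(O)(CSc1ccc(OC(F)(F)F)cc1)C(=O)Nc1cccc(S(F)(F)(F)(F)F)c1`: 28500 nM

In a functional assay on VCaP cells (Homo sapiens) for antiproliferative activity, read by propidium iodide staining, with a stated time of 96 h (on this read-out higher numbers stand for weaker inhibition and lower numbers for stronger inhibition), these three compounds sit close together. Compound 1 and compound 2 are the same atoms joined differently (2-(trifluoromethyl)phenyl in place of 4-(trifluoromethyl)phenyl on a sulfur), and a 1.3-fold lower number from compound 1 to compound 2 (0.11 log units; within the scatter). Compound 3 is reached from compound 1 by the change (trifluoromethoxy in place of trifluoromethyl on an aromatic carbon), which gave a 1.0-fold higher number from compound 1 to compound 3 (0.02 log units; within the scatter). The unmeasured compound 4 `CC(O)(CSc1ccccc1OC(F)(F)F)C(=O)Nc1cccc(S(F)(F)(F)(F)F)c1` is reached from compound 2 by the same kind of change, (trifluoromethoxy in place of trifluoromethyl on an aromatic carbon); the place differs, para to a large group in the first case and ortho to a large group here. Because a 1.0-fold higher number from compound 1 to compound 3 (0.02 log units; within the scatter) stayed within the scatter, compound 4 is expected to give a step of a 1.0-fold higher number from compound 2 to compound 4 (0.02 log units; within the scatter) in this assay. Compound 4 is therefore estimated at 22000 nM, with a likely range from 10000 nM to 48000 nM.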

Compound 4, half-maximal inhibitory concentration: 12600 nM
Estimate against measurement, compound 4: 1.7-fold (0.24 log units) above; measured number inside the range.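

Trifluoromethoxy in place of trifluoromethyl, ortho to a large group, gave a 1.7-fold lower number from compound 2 to compound 4 (0.22 log units; within the scatter) in this assay. Set beside the earlier step on the other core, the change carries across without a difference that stands out from the scatter: the same change on two cores in this assay, a 1.0-fold higher number (0.02 log units; within the scatter) from compound 1 to compound 3 and a 1.7-fold lower number (0.22 log units; within the scatter) from compound 2 to compound 4, 1.7-fold (0.24 log units) apart, within the scatter of two such steps. Going by these compounds alone, this shows only that the two pairs agree within the noise of the measurements; it does not show that the change has no effect on a core, and two pairs cannot establish that it would carry to a further core.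

The compounds shown leave open how a nitrile, a methoxy group or a chlorine would behave in place of these two groups. They also leave open what an amine or a carboxylic acid in place of the hydroxyl would do.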